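The source may report more compounds than this note shows. Statements on the series, on what has been measured and on what is new or still open speak of the compounds shown alone.

Of the compounds shown here, three have been measured in an assay on isolated protein for inhibition of leukotriene B4 receptor 1 (Homo sapiens); on this read-out higher numbers stand for weaker inhibition and lower numbers for stronger inhibition: compound 1 `CCCc1c(OCCCOc2ccc(C(=O)N(C)C)c(OC)c2CCC)ccc2c1OC(C(=O)O)CC2` with 0.15 nM; compound 2 `CCCc1c(OCCCOc2ccc(C(=O)NC)c(OC)c2CC2CC2)ccc2c1OC(C(=O)O)CC2` with 5.3 nM; compound 3 `CCCc1c(OCCCOc2ccc(C(=O)NC)c(OC)c2CC2CC2)ccc2c1O[C@@H](CCC(=O)O)CC2` with 8.5 nM.

Compound 1 stands lowest of the three numbers, and both other compounds lie beyond the scatter above it, compound 2 nearer and compound 3 furthest. Neither compound 2 nor compound 3 differs from compound 1 in a single place, so their values cannot be pinned to one change; they only show that the amide carries a smaller substituent in both weaker compounds alongside other changes.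

Compound 4 `CCCc1c(OCCCOc2ccc(C(N)=O)c(OC)c2CCC)ccc2c1OC(C(=O)O)CC2` is the next compound, and it differs from compound 1 by amino in place of dimethylamino on a carbonyl carbon. Within the data shown here, no measured pair isolates this change in this assay. Given that compound 2 and compound 3, whose amides also carry fewer methyl groups, sit well above compound 1, a loss that goes somewhat beyond the scatter is expected for compound 4, though smaller than those gaps since only the amide is altered. The estimated step of a 4.0-fold higher number from compound 1 to compound 4 (0.60 log units; beyond the scatter) is a moderate weakening. For compound 4 the expected value in this assay is 0.6 nM, within a range from 0.15 nM to 3 nM.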

Compound 4, half-maximal inhibitory concentration: 2.4 nM
Estimate against measurement, compound 4: 4.0-fold (0.60 log units) below, within the range that was stated.
By their numbers in this assay, from the lowest: compound 1; then compound 4; then compounds 2 and 3 (each within the scatter of the next).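

Among these compounds, exchanging dimethylamino for amino on a carbonyl carbon is the first change in this set that can be read on its own, and in this assay it produces a large step, a 16-fold higher number from compound 1 to compound 4 (1.20 log units; beyond the scatter), with the rest of the core of compound 1 unchanged. The result shows that this position is sensitive to what the amide nitrogen carries, with the dimethylcarbamoyl group of compound 1 giving much stronger inhibition than the carbamoyl group of compound 4. Nothing available explains the size of this step.

As far as these compounds go, whether diethylamino or a pyrrolidine ring on the same carbonyl carbon would match compound 1 remains open. From the compounds shown here alone, compounds 2 and 3 differ from compound 1 and compound 4 in more than one place, so those steps cannot be read, and the effect of methylamino alone on this core remains unknown.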